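A few compounds are considered here, and "the series" means these few. Any claim that something is new, unique, unknown or untested is made for them only; others in the source may bear on it.

Measured compounds in an assay on HepG2 cells for agonist activity at nuclear receptor subfamily 1 group I member 3 (Homo sapiens), read by a luciferase reporter, with a stated time of 23 h; a higher number here means that more compound is needed for the effect, a lower number that less compound is needed:
- compound 1 `CC(C)(C)c1ccc(CO/N=C/c2c(-c3ccc4ccccc4c3)nc3occn23)cc1`: 7900 nM
- compound 2 `C(=N/OCc1ccccc1)\c1c(-c2ccc3ccccc3c2)nc2occn12`: 840 nM
- compound 3 `Clc1ccc(CO/N=C/c2c(-c3ccc4ccccc4c3)nc3occn23)c(Cl)c1`: 1500 nM

Compound 3 stands second highest of the three numbers in this assay; its nearest neighbour is compound 2, within the scatter, and its furthest is compound 1, beyond it. Compound 4 `Fc1c(F)c(F)c(CO/N=C/c2c(-c3ccc4ccccc4c3)nc3occn23)c(F)c1F` differs from compound 3 in one place: 2,3,4,5,6-pentafluorophenyl in place of 2,4-dichlorophenyl on a saturated chain carbon bound to an oxygen on an unsaturated carbon. Going by the values given here, two measured steps bear on this position. The step of a 1.8-fold higher number from compound 2 to compound 3 (0.25 log units; within the scatter) was within the scatter, while the step of a 5.3-fold lower number from compound 1 to compound 3 (0.72 log units; beyond the scatter) was modest. Exchanging one substituted aryl group for another at this carbon has so far moved the number little or modestly, so no shift beyond the scatter is expected for compound 4, with the step of no change at the digits printed from compound 3 to compound 4 (within the scatter) estimated. Compound 4 is expected to give 1500 nM, in the range 500 nM to 4500 nM.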

Compound 4, half-maximal effective concentration: 1700 nM
Compound 4: the middle estimate sits 1.1-fold (0.05 log units) below what was measured; the range from low to high includes it.
By their numbers in this assay, from the lowest: compounds 2, 3 and 4 (each within the scatter of the next, the first and the last beyond it); then compound 1.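

In this assay, swapping 2,4-dichlorophenyl for 2,3,4,5,6-pentafluorophenyl at this carbon leaves the number unchanged within the scatter (a 1.1-fold higher number from compound 3 to compound 4 (0.05 log units; within the scatter)), so five fluorines and two chlorines on the ring read alike here. Against plain phenyl, however, the pentafluorophenyl group gives a step just beyond the scatter (a 2.0-fold higher number from compound 2 to compound 4 (0.31 log units; beyond the scatter)), which the dichlorophenyl group did not. The 4-(tert-butyl)phenyl compound stays apart from this halogenated pair (a 4.6-fold lower number from compound 1 to compound 4 (0.67 log units; beyond the scatter)).

Nothing available explains these differences. As far as these compounds go, whether a methoxy group, a nitrile or an amine on the ring would fit this range remains open.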